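Swapping the aromatic end group of compound 3

A few compounds are considered here, and "the series" means these few. Any claim that something is new, unique, unknown or untested is made for them only; others in the source may bear on it.

Measured so far in a functional assay (aorta) with Oryctolagus cuniculus as the target; a higher number here means weaker binding, a lower number tighter binding:
- compound 1 `COc1cc(C(C)=O)ccc1OCCCN1CCC(C(c2cccc(F)c2)c2cccc(F)c2)CC1` gives 3.16 nM here
- compound 2 `COc1cc(C(C)O)ccc1OCCCN1CCC(C(c2ccc(F)cc2)c2ccc(F)cc2)CC1` gives 10 nM here
- compound 3 `COc1cc(C#N)ccc1OCCCN1CCC(C(c2ccc(F)cc2)c2ccc(F)cc2)CC1` gives 2 nM here

Compound 3 and compound 1 lie within the usual scatter of each other, so these two cannot be told apart. Compound 2 stands clearly apart from compound 3, and the measured step is a 5.0-fold lower number from compound 2 to compound 3 (0.70 log units; beyond the scatter) in this series.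

Compound 4 `Fc1ccc(C(c2ccc(F)cc2)C2CCN(CCCOc3ccc(Cl)cc3)CC2)cc1` has not yet been measured. It keeps the shared core of compound 3 but carries 4-chlorophenyl in place of 4-cyano-2-methoxyphenyl on an oxygen on a saturated carbon. Going by the values given here, only one measured step bears on this change. The swap from compound 2 to compound 3 also altered a group on this aromatic ring, and its size, a 5.0-fold lower number from compound 2 to compound 3 (0.70 log units; beyond the scatter) as shown, was modest. Among the compounds with values here, that step is only a loose guide, since no measured compound lacks the methoxy group or carries chlorine. A modest move toward a higher number in this assay is therefore expected, estimated as a 4.0-fold higher number from compound 3 to compound 4 (0.60 log units; beyond the scatter) with wide uncertainty. For compound 4 the estimated value is 8 nM with an expected range from 1.5 nM to 40 nM in this series.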

Compound 4, dissociation constant: 2 nM
Beside the measured number, compound 4's estimate is 4.0-fold (0.60 log units) above it, within the range that was stated.
By their numbers in this assay, from the lowest: compounds 3, 4 and 1 (each within the scatter of the next); then compound 2.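

In this assay, the step is no change at the digits printed from compound 3 to compound 4 (within the scatter), so the whole end group on the oxygen can change from 4-cyano-2-methoxyphenyl to 4-chlorophenyl with no difference that can be read, even though the nitrile, the methoxy group and both hydrogen-bond acceptors leave together. The earlier compounds had changed only one group on a ring that kept its methoxy group, whereas this result shows that neither the methoxy group nor the nitrile is needed for a low number among these compounds, and the comparison with the 1-hydroxyethyl compound gives a 5.0-fold lower number from compound 2 to compound 4 (0.70 log units; beyond the scatter), the same size as the step to the nitrile compound. No measurement shown here explains why these two different end groups give matching results.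

Going by these compounds, the methoxy group and the nitrile left in a single step, so what each contributes alone stays unknown, and chlorine is the only simple replacement on this ring seen so far. On these data alone, it also remains open whether an amine or a carboxylic acid in place of the chlorine, or a longer chain between the oxygen and the ring nitrogen, would hold the number at this level.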